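Methoxy for Trifluoromethyl in a Weakly Cytotoxic Series

This account rests on a few compounds, and the source may have more. Where it says the series, first, only, none or still open, it means among the compounds named here.

Measured so far:
compound 1, `COc1ccc(-c2nc(C(=O)/C=C\Nc3ccc4[nH]ccc4c3)c3ccccn23)cc1`: 28700 nM
compound 2, `O=C(/C=C\Nc1ccc(F)cc1)c1nc(-c2ccc(C(F)(F)F)cc2)n2ccccc12`: > 30000 nM

Of the compounds shown here, two have been tested in a functional assay on MDA-MB-231 cells (Homo sapiens) for cytotoxicity, read by MTT assay, with a stated time of 48 h; on this read-out higher numbers stand for weaker inhibition and lower numbers for stronger inhibition. Compound 1 `COc1ccc(-c2nc(C(=O)/C=C\Nc3ccc4[nH]ccc4c3)c3ccccn23)cc1` gives 28700 nM. Compound 2 `O=C(/C=C\Nc1ccc(F)cc1)c1nc(-c2ccc(C(F)(F)F)cc2)n2ccccc12` reaches only a limit of the assay, reported as > 30000 nM. Compound 2 thus stands at the limit of > 30000 nM in this assay, at which 1 of the 2 values shown sits, and no number places it relative to compound 1.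

Compound 3 `COc1ccc(-c2nc(C(=O)/C=C\Nc3ccc(F)cc3)c3ccccn23)cc1` has not been measured. It differs from compound 2 in one place: methoxy in place of trifluoromethyl on an aromatic carbon. Among the compounds with values here, no step between two measured compounds covers this change. Compound 1 also bears the methoxy group and gives 28700 nM in this assay, which leaves no ground to expect a step beyond the scatter in either direction. Compound 3 is therefore expected to give about 30000 nM in this assay, with a range from 12000 nM to 80000 nM. The expected step, a number no higher from compound 2 to compound 3 (the limit leaves the size open), is estimated to stay within the scatter, and a limit rather than a number is quite likely.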

Compound 3, half-maximal inhibitory concentration: > 30000 nM
Compound 3 was reported as a limit (the forecaster's own chance of this, stated with the estimate: 60%); the middle value sits exactly at the limit.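

Methoxy on this aromatic carbon, para to a large group, does not bring the compound to a readable number in this assay: compound 3 is reported only as a limit, > 30000 nM. The step between the two limits cannot be read, so this change has no measurable size here, and the limit now holds most of the series: the limit of > 30000 nM in this assay, at which 2 of the 3 values shown sit. The other change, 4-fluorophenyl in place of 1H-indol-5-yl on the amine nitrogen, gives an at least 1.0-fold higher number from compound 1 to compound 3 (0.01 log units; that floor lies within the scatter), so it shows no difference that can be told from scatter.

From the compounds shown here alone, how an amine or a carboxylic acid at the methoxy position would read in this assay stays open. Also open, going by these compounds, is whether 1H-indol-5-yl on the amine nitrogen would give a number with trifluoromethyl in place of methoxy.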